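Swapping the aryl group on the triazole in a weak series

The source may report more compounds than this note shows. Statements on the series, on what has been measured and on what is new or still open speak of the compounds shown alone.

Measured so far:
Compound 1, `N#CC1=C(N)Oc2c(N)cc3nc4ccccc4nc3c2C12C(=O)N(Cc1cnnn1-c1c(F)cccc1F)c1ccccc12`, in a functional assay on MCF7 cells (Homo sapiens) for antiproliferative activity, read by MTT assay, with a stated time of 48 h (on this read-out higher numbers stand for weaker inhibition and lower numbers for stronger inhibition), gives > 50000 nM, which is a limit of the assay rather than a number.
Compound 2, `COc1ccc(OC)c(-n2nncc2CN2C(=O)C3(C(C#N)=C(N)Oc4c(N)cc5nc6ccccc6nc5c43)c3ccccc32)c1`, in this assay gives 28100 nM.

Among the compounds with values here, compound 2 is therefore the only member of the pair with a measured number; compound 1 sits at the limit described by the limit of > 50000 nM in this assay, at which 1 of the 2 values shown sits. Within the data shown here, the one measured step, an at least 1.7-fold lower number from compound 1 to compound 2 (0.25 log units; that floor lies within the scatter), is only a floor, and it lies within the usual scatter, so it shows at most a modest difference between the two aryl groups on the triazole nitrogen.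

Compound 3, `Cc1ccc(Cl)cc1-n1nncc1CN1C(=O)C2(C(C#N)=C(N)Oc3c(N)cc4nc5ccccc5nc4c32)c2ccccc21`, is the next compound to be tested. Its change from compound 2 is 5-chloro-2-methylphenyl in place of 2,5-dimethoxyphenyl on an aromatic nitrogen. Among the measured compounds shown here, the only comparable step, an at least 1.7-fold lower number from compound 1 to compound 2 (0.25 log units; that floor lies within the scatter), gives little guidance on size or direction, since it is a floor within the scatter. The expectation is therefore a number close to that of compound 2, with wide uncertainty. Compound 3 is expected to give 30000 nM in this assay, within a range from 10000 nM to 90000 nM. That estimate corresponds to a step of a 1.1-fold higher number from compound 2 to compound 3 (0.03 log units; within the scatter), which is within the scatter.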

Compound 3, half-maximal inhibitory concentration: 43500 nM
Compound 3: middle estimate off by 1.5-fold (0.16 log units), on the low side; the range from low to high includes it.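

Within the data shown here, on the aromatic nitrogen, the 2 hydrogen-bond acceptors of 2,5-dimethoxyphenyl leave with this change and none enter, yet in this assay the step is a 1.5-fold higher number from compound 2 to compound 3 (0.19 log units; within the scatter), so the first step in this set between two measured numbers does not tell these two groups apart. The other new step, an at least 1.1-fold lower number from compound 1 to compound 3 (0.06 log units; that floor lies within the scatter), is only a floor, and it also gives no sign of a real difference between 5-chloro-2-methylphenyl and 2,6-difluorophenyl. Three differently substituted phenyl groups on this nitrogen now show no step beyond the scatter, and part of the picture is capped by an assay limit: the limit of > 50000 nM in this assay, at which 1 of the 3 values shown sits.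

All the groups shown are substituted phenyl rings, so it remains open whether a different kind of group here, such as a pyridine ring, a carboxylic acid or a simple alkyl chain, would give a number clearly apart from these. As far as these compounds go, it also remains open whether these high numbers belong to the shared core rather than to this position, which only changes elsewhere on the core could show.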